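The source may report more compounds than this note shows. Statements on the series, on what has been measured and on what is new or still open speak of the compounds shown alone.

Measured so far in a functional assay on HepG2 cells (Homo sapiens) for cytotoxicity, read by MTT assay, with a stated time of 48 h; on this read-out lower numbers stand for stronger inhibition and higher numbers for weaker inhibition:
compound 1 `O=c1cc(-c2ccc([N+](=O)[O-])cc2)oc2ccc(CN3CCCCC3)cc12` gives "not determined" (no result reported)
compound 2 `O=c1cc(-c2ccc(Cl)cc2)oc2ccc(CN3CCCCC3)cc12` gives 14000 nM
compound 3 `O=c1cc(-c2ccc(Cl)cc2)oc2ccc(Cn3ccnc3)cc12` gives "not determined" (no result reported)

Among the measured compounds shown here, compound 2 (14000 nM) holds the only number, so it cannot yet be ranked against any other compound. Compound 4 `Nc1ccc(-c2cc(=O)c3cc(CN4CCCCC4)ccc3o2)cc1` is still unmeasured and differs from compound 2 by amino in place of chloro on an aromatic carbon. For the measured compounds named here, no step between measured compounds is available to size this change, so no step beyond the usual scatter is expected in this assay in either direction. The expected step is a 1.3-fold higher number from compound 2 to compound 4 (0.11 log units; within the scatter) on this estimate, with wide uncertainty. The estimated value for compound 4 is 18000 nM (expected range 6000 nM to 60000 nM).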

Compound 4, half-maximal inhibitory concentration: 2640 nM
For compound 4 the middle estimate is 6.8-fold (0.83 log units) above the measured one; measured number outside the range, below it.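

In this assay, going from 4-chlorophenyl to 4-aminophenyl gives a 5.3-fold lower number from compound 2 to compound 4 (0.72 log units; beyond the scatter). Among the compounds shown here, this is the first sign that the read-out responds to a change on this aromatic carbon, para to a large group. No available data explain the step.

Compound 1 and compound 3 have no reported result, so steps involving them cannot be read. From the compounds shown here alone, whether a hydroxyl or methoxy group at this position would match the amino group remains open, as does whether a longer amine chain would preserve the lower number.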